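Adding a 1,3-oxazol-2-yl Group to Compound 3

The compounds below may be only part of what the source reports. "The series", "measured", "known", "first", "only" and "open" are said of these compounds alone.

Measured compounds:
- compound 1, `c1cc(-c2cn[nH]c2)c2c(c1)C(c1ncc[nH]1)CC2`: 14 nM
- compound 2, `c1ccc(-c2cccc3c2CCC3c2ncc[nH]2)nc1`: 1150 nM
- compound 3, `c1ccc2c(c1)CCC2c1ncc[nH]1`: 473 nM

In a functional assay on CHO cells for agonist activity at Alpha-1A adrenergic receptor (Homo sapiens), read by FLIPR and calcium flux (on this read-out higher numbers stand for an effect only at larger amounts of compound and lower numbers for an effect already at smaller amounts), compound 3 gives 473 nM, the second highest number of the three measured compounds; compound 2 gives 1150 nM and compound 1 gives 14 nM. Compound 4, `c1cc(-c2ncco2)c2c(c1)C(c1ncc[nH]1)CC2`, has not been measured. It differs from compound 3 as follows: 1,3-oxazol-2-yl in place of hydrogen on an aromatic carbon.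

Among the compounds with values here, two measured steps bear on the same position. From compound 1 to compound 3, a 34-fold higher number from compound 1 to compound 3 (1.53 log units; beyond the scatter), so a 1H-pyrazol-4-yl group at this carbon goes with a far lower number than hydrogen. From compound 2 to compound 3, a 2.4-fold lower number from compound 2 to compound 3 (0.39 log units; beyond the scatter), so a pyridin-2-yl group goes with a somewhat higher number than hydrogen. Within the data shown here, the entering 1,3-oxazol-2-yl is, like 1H-pyrazol-4-yl, a five-membered aromatic ring with two hetero atoms, but it carries no hydrogen-bond donor, so the writer expects a downward step for compound 4 that is smaller than the one seen with compound 1, estimated as a 4.7-fold lower number from compound 3 to compound 4 (0.67 log units; beyond the scatter). The estimate for compound 4 is 100 nM, with a range from 25 nM to 400 nM.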

Compound 4, half-maximal effective concentration: 170 nM
Estimate against measurement, compound 4: 1.7-fold (0.23 log units) below, within the range that was stated.
By their numbers in this assay, from the lowest: compound 1; then compound 4; then compound 3; then compound 2.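

In this assay, the 1,3-oxazol-2-yl group shows that a five-membered aromatic ring with 0 hydrogen-bond donors on this aromatic carbon still goes with a lower number than hydrogen (a 2.8-fold lower number from compound 3 to compound 4 (0.44 log units; beyond the scatter)). The same ring also sits well under pyridin-2-yl (a 6.8-fold lower number from compound 2 to compound 4 (0.83 log units; beyond the scatter)) but clearly above 1H-pyrazol-4-yl (a 12-fold higher number from compound 1 to compound 4 (1.08 log units; beyond the scatter)), so the three aromatic rings at this carbon give three separate levels, not one shared shift from hydrogen. No supporting measurement here accounts for these gaps.

Going by these compounds, whether the hydrogen-bond donor count is what separates 1H-pyrazol-4-yl from 1,3-oxazol-2-yl remains open, since the two rings differ in more than that count. Also open, on these data alone, is how a non-aromatic substituent on this carbon, such as an amine or a short alkyl chain, or a plain phenyl ring would compare.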